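Alpha-Isobutyl on the Glycinamide Arm: Estimating Compound 4

This account rests on a few compounds, and the source may have more. Where it says the series, first, only, none or still open, it means among the compounds named here.

The series is compared in a functional assay on the whole organism (Tail, strain ICR) with Mus musculus as the target, in the tail flick test, with a stated time of 30 min, at a dose of 25 umol/kg by the oral route; a lower number here means a weaker effect, a higher number a stronger effect of the compound at the dose given. Among the measured compounds shown here, compound 2 `O=C(CN(c1nc(Cl)nc2[nH]cnc12)C1CC1)NCC(=O)OCc1ccccc1` gives 18.7%, the lowest of the three numbers so far. Compound 3 `O=C(O)CNC(=O)CN(c1nc(Cl)nc2[nH]cnc12)C1CC1` gives 32.2%. Compound 1 `NC(=O)CC[C@H](NC(=O)CN(c1ncnc2c1ncn2C1CCCCO1)C1CC1)C(=O)OCc1ccccc1` differs from compound 2 in several places, and in this assay compound 1 gives 47%. For the measured compounds named here, the only single-point step measured so far is a number 13.5 percentage points higher from compound 2 to compound 3 (beyond the scatter), and it concerns hydrogen in place of benzyl on an oxygen next to a carbonyl group, not the chain carbon changed here.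

Compound 4 `CC(C)C[C@H](NC(=O)CN(c1nc(Cl)nc2[nH]cnc12)C1CC1)C(=O)OCc1ccccc1` differs from compound 2 by isobutyl in place of hydrogen on a saturated chain carbon bound to an amide-type nitrogen and a carbonyl carbon. Going by the values given here, no measured step addresses this position. Compound 1 carries a larger substituent pattern and gives 47%, but its number cannot be tied to any single change. Among the compounds with values here, with no direct precedent, the expected step of a number 9.3 percentage points higher from compound 2 to compound 4 (within the scatter) is taken as a small rise, close to the scatter. Compound 4 is therefore estimated at 28%, with a range from 10% to 50%.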

Compound 4, a percentage reported as activity, at one dose (the size of the read-out at that dose, not a potency): 33.9%
Estimate against measurement, compound 4: 5.9 percentage points below; measured number inside the range.
By their numbers in this assay, from the lowest: compound 2; then compounds 3 and 4 (each within the scatter of the next); then compound 1.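

In this assay, the saturated chain carbon bound to an amide-type nitrogen and a carbonyl carbon responds to substitution: isobutyl in place of hydrogen gives a number 15.2 percentage points higher from compound 2 to compound 4 (beyond the scatter). The earlier single-point step concerned benzyl on an oxygen next to a carbonyl group, whereas this one shows that the number can also move with that benzyl kept in place, through a change on the chain carbon alone. No available evidence accounts for this rise.

On these data alone, with only hydrogen and isobutyl compared at this carbon, the effect of a methyl, a longer chain, an amine or a carboxylic acid there remains open. Also open, as far as these compounds go, is whether the isobutyl step carries over to the series member with hydrogen in place of benzyl, which would pair isobutyl with a free carboxylic acid.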